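Series notes: cyclopropyl to 2-methylphenyl at the chain carbon

The source may hold more compounds than are shown below. What is called first, only, known or untested is meant among the compounds shown, and "the series" means these compounds.

Compound 3 `O=C(C1CC1)N1CCN(Cc2nc3ccccc3n2CC2CC2)CC1` gives the lowest number of the three measured compounds in an assay on isolated protein for inhibition of aldehyde dehydrogenase 1A1 (Homo sapiens), read by spectrophotometry, tested at 10 uM (a lower number here means less inhibition, a higher number more inhibition at the concentration tested (going by the name of the read-out)), with 21.2%. Compound 1 `Cc1ccc(Cn2c(CN3CCN(C(=O)C4CC4)CC3)nc3ccccc32)cc1` gives 51.5% and compound 2 `CC(C)CCn1c(CN2CCN(C(=O)C3CC3)CC2)nc2ccccc21` gives 70%; the steps down to compound 3 are a number 30.3 percentage points lower from compound 1 to compound 3 (beyond the scatter) and a number 48.8 percentage points lower from compound 2 to compound 3 (beyond the scatter). Compound 4 `Cc1ccccc1Cn1c(CN2CCN(C(=O)C3CC3)CC2)nc2ccccc21` has not yet been measured; it differs from compound 3 by 2-methylphenyl in place of cyclopropyl on a saturated chain carbon bound to an aromatic nitrogen. The step from compound 1 to compound 3, which exchanges the 4-methylphenyl of compound 1 for cyclopropyl, bears most directly on this change and was large; the step from compound 2 to compound 3 was larger still. Both point the same way: putting a methyl-bearing phenyl back in place of cyclopropyl is expected to raise the number in this assay by a large step. Compound 4 is therefore expected to read 50%, between 30% and 70%, an expected step of a number 28.8 percentage points higher from compound 3 to compound 4 (beyond the scatter). Only compound 1 carries a methyl-bearing phenyl at this position, so the range is kept wide.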

Compound 4, a percentage reported as inhibition, at one concentration (the size of the read-out at that concentration, not a potency): 29.1%
Estimate against measurement, compound 4: 20.9 percentage points above; the whole stated range lies above it.
By their numbers in this assay, from the lowest: compounds 3 and 4 (each within the scatter of the next); then compound 1; then compound 2.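

In this assay, 2-methylphenyl in place of cyclopropyl at this position gives a number 7.9 percentage points higher from compound 3 to compound 4 (within the scatter), so carrying an aromatic ring here does not on its own separate compound 4 from compound 3. The two methylphenyl groups do not read alike: moving from 4-methylphenyl to 2-methylphenyl gives a number 22.4 percentage points lower from compound 1 to compound 4 (beyond the scatter), and the change from isobutyl gives a number 40.9 percentage points lower from compound 2 to compound 4 (beyond the scatter), which leaves the methyl placement on the phenyl ring as a difference that matters in this short series. No measurement at hand accounts for these differences.

The compounds shown leave open how an unsubstituted phenyl on the same chain carbon would read against the two methylphenyl groups. They also leave open whether a longer chain than the isobutyl of compound 2 would continue the trend from cyclopropyl to isobutyl.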